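Ring Size at the Thiocarbonyl Carbon: Compound 4

This account rests on a few compounds, and the source may have more. Where it says the series, first, only, none or still open, it means among the compounds named here.

Compounds measured so far:
compound 1, `Cc1cccc(/C(N)=N/NC(=S)N2CCSCC2)n1`, 77.4%
compound 2, `Cc1cccc(/C(N)=N/NC(=S)N2CCOCC2)n1`, 83.8%
compound 3, `Cc1cccc(/C(N)=N/NC(=S)N2CCCCC2)n1`, 85.7%

In a functional assay on A-375 cells (Homo sapiens) for cytotoxicity, read by MTT assay, with a stated time of 72 h, tested at 100 uM (a lower number here means less inhibition of growth, a higher number more inhibition of growth at the concentration tested), compound 3 gives the highest of the three numbers, but the steps leading to it are small: a number 8.3 percentage points higher from compound 1 to compound 3 (within the scatter), a number 1.9 percentage points higher from compound 2 to compound 3 (within the scatter), and a number 6.4 percentage points higher from compound 1 to compound 2 (within the scatter). None of the three measured compounds can therefore be set apart from the others.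

Compound 4, `Cc1cccc(/C(N)=N/NC(=S)N2CCCC2)n1`, is the next member of the series. It differs from compound 3 in one place: pyrrolidin-1-yl in place of piperidin-1-yl on a thiocarbonyl carbon. Going by the values given here, no measured step swaps one ring size for another at this position; the steps that exist exchange six-membered rings among themselves, and each stays inside the scatter. Among the compounds with values here, the only guidance available is that every change at the thiocarbonyl carbon so far has left this assay essentially unmoved. Compound 4 is therefore expected to lie close to compound 3, with an estimated step of a number 3.7 percentage points lower from compound 3 to compound 4 (within the scatter), meaning no change beyond the scatter. The estimate for compound 4 is 82%, with a range from 68% to 94%.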

Compound 4, percent growth inhibition at one concentration: 66.3%
The estimate for compound 4 lay 15.7 percentage points above the measured number; the whole stated range lies above it.
By their numbers in this assay, from the lowest: compound 4; then compounds 1, 2 and 3 (each within the scatter of the next).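

In this assay, the substituent on the thiocarbonyl carbon had shown no step beyond the scatter while it stayed a six-membered ring, but pyrrolidin-1-yl now gives one against each of them (a number 19.4 percentage points lower from compound 3 to compound 4 (beyond the scatter); a number 17.5 percentage points lower from compound 2 to compound 4 (beyond the scatter); a number 11.1 percentage points lower from compound 1 to compound 4 (beyond the scatter)). Among these four compounds, the position therefore responds to the change from a six-membered to a five-membered ring, and compound 4 stands apart from compounds 1, 2 and 3, while exchanging the ring members among the six-membered rings leaves no step beyond the scatter. Nothing available explains why the smaller ring lowers the number.

Going by these compounds, this rests on a single five-membered ring, so it remains open whether a seven-membered azepan-1-yl ring or an open-chain dimethylamino group would lie with compound 4 or with the six-membered rings. On these data alone, it also remains open whether a substituted pyrrolidin-1-yl ring, such as one carrying a methyl group, would behave like compound 4.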